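Working notes on a weakly antiproliferative series

A few compounds are considered here, and "the series" means these few. Any claim that something is new, unique, unknown or untested is made for them only; others in the source may bear on it.

Measured so far in a functional assay on CFPAC-1 cells (Homo sapiens) for antiproliferative activity, read by MTT assay, with a stated time of 72 h; on this read-out lower numbers stand for stronger inhibition and higher numbers for weaker inhibition:

- compound 1, `O=C1O[C@H]([C@@H](O)Cn2cc(CNS(=O)(=O)c3ccc(F)cc3)nn2)C(OCc2ccccc2)=C1OCc1ccccc1`, gives 34700 nM.
- compound 2, `CC(C)(C)OC(=O)N1CCN(C(=S)SCc2cn(C[C@H](O)[C@H]3OC(=O)C(OCc4ccccc4)=C3OCc3ccccc3)nn2)CC1`, gives > 100000 nM, which is a limit of the assay and not a number.

Among the compounds with values here, compound 1 carries the only numeric value in this assay; the other measured entry sits at the limit of > 100000 nM in this assay, at which 1 of the 2 values shown sits, so compound 1 cannot be ranked against it beyond the fact that it returns a number at all. Both measured compounds share the same core; they differ in the group hanging from the triazole-linked chain, and that difference is not a single-point step, so no measured step size is available.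

Compound 3, `O=C1O[C@H]([C@@H](O)Cn2cc(CCCCl)nn2)C(OCc2ccccc2)=C1OCc1ccccc1`, is the next member. Relative to compound 1 the change is 2-chloroethyl in place of ((4-fluorophenyl)sulfonyl)amino on a saturated chain carbon bound to an aromatic carbon.

Within the data shown here, with no measured step to lean on, the expectation rests on compound 1 alone. The expected step is a 1.2-fold higher number from compound 1 to compound 3 (0.06 log units; within the scatter), which is not clearly beyond the usual scatter in either direction. Compound 3 is therefore estimated at 40000 nM in this assay, with a range from 15000 nM to 100000 nM.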

Compound 3, half-maximal inhibitory concentration: 58800 nM
Estimate against measurement, compound 3: 1.5-fold (0.17 log units) below; the range from low to high includes it.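

In this assay, the step is a 1.7-fold higher number from compound 1 to compound 3 (0.23 log units; within the scatter), so replacing ((4-fluorophenyl)sulfonyl)amino with 2-chloroethyl on a saturated chain carbon bound to an aromatic carbon gives no difference that can be told from the usual scatter. This holds although the change is large in structure: the leaving group has 11 heavy atoms, an aromatic ring, a hydrogen-bond donor and hydrogen-bond acceptors, while the entering group has 3 heavy atoms and none of these features. The numeric value of compound 3 therefore shows that, on the shared core, the ((4-fluorophenyl)sulfonyl)amino group is not needed for a numeric reading in this series, and no measured property in these notes bears on this result.

Both numeric values remain weak, and this single step does not show whether any group at this position can move the number beyond the scatter. From the compounds shown here alone, an amine, a carboxylic acid or a longer chain ending in chlorine at the same place would test this, and the contribution of the shared core to the values remains open.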